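The compounds below may be only part of what the source reports. "The series", "measured", "known", "first", "only" and "open" are said of these compounds alone.

Compound 2, with the structure `Nc1cc(N)c2nc(-c3ccccc3)c(Sc3ccc(Cl)c(Cl)c3)nc2c1`, belongs to a small group of compounds with a shared core. In a functional assay on SNB-19 cells (Homo sapiens) for inhibition, read by sulforhodamine B assay, with a stated time of 48 h (a lower number here means that less compound is tolerated, a higher number that more compound is tolerated), compound 2 gives < 100000 nM, which is a limit of the assay and not a number. Its neighbour compound 1, with the structure `Nc1cc(N)c2nc(-c3ccccc3)c(Oc3ccc(Cl)c(Cl)c3)nc2c1`, is the same except for the attachment on the core. In this assay compound 1 likewise gives < 100000 nM, again a limit rather than a number. The step between them, a step that the two limits leave unreadable from compound 1 to compound 2, therefore stays unreadable, and all that both values show is the limit of < 100000 nM in this assay, at which 2 of the 2 values shown sit.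

Compound 3, with the structure `Nc1cc(N)c2nc(-c3ccccc3)c(Oc3ccc(F)cc3)nc2c1`, is not yet measured. It differs from compound 2 by 4-fluorophenoxy in place of (3,4-dichlorophenyl)sulfanyl on an aromatic carbon. Within the data shown here, no measured step bears on this exchange, since the one step available is hidden by its limits. Given that compound 2 sits at a limit, compound 3 is expected to stay near the same place, with a step that the limit leaves unreadable from compound 2 to compound 3 in this assay. The estimate for compound 3 is 60000 nM, with a range from 15000 nM to 100000 nM.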

Compound 3, concentration lethal to 50% of the cells: 66100 nM
For compound 3 the middle estimate is 1.1-fold (0.04 log units) below the measured one, within the range that was stated.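

Among these compounds, compound 3 has a measured value in this assay, but no step from compound 1 or compound 2 to compound 3 can be read, since compound 1 and compound 2 each stand only at a limit of the assay: the limit of < 100000 nM in this assay, at which 2 of the 3 values shown sit.

The compounds shown leave open whether exchanging 3,4-dichlorophenoxy, (3,4-dichlorophenyl)sulfanyl or 4-fluorophenoxy on the shared core changes the result at all.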